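Working notes: changing the group on the carbonyl carbon

A few compounds are considered here, and "the series" means these few. Any claim that something is new, unique, unknown or untested is made for them only; others in the source may bear on it.

Values measured in a functional assay on B16-F10 cells (Mus musculus) for antiproliferative activity, read by MTT assay, with a stated time of 48 h (on this read-out higher numbers stand for weaker inhibition and lower numbers for stronger inhibition), for this series:
compound 1 `COc1ccc(/C=C/c2cc(OC)cc(OC)c2/C=C/C(=O)c2ccc(Cl)c(Cl)c2)cc1` gives 7.5 ug/mL
compound 2 `CCCCOc1ccc(C(=O)/C=C/c2c(/C=C/c3ccc(OC)cc3)cc(OC)cc2OC)cc1` gives 5.3 ug/mL
compound 3 `COc1ccc(/C=C/c2cc(OC)cc(OC)c2/C=C/C(=O)c2cccc(Cl)c2)cc1` gives 3.3 ug/mL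

Compound 3 sits at the low end of these three numbers, with a 2.3-fold lower number from compound 1 to compound 3 (0.36 log units; beyond the scatter) as a modest step beyond the scatter and a 1.6-fold lower number from compound 2 to compound 3 (0.21 log units; within the scatter) as one within it. The next compound is compound 4 `COc1ccc(/C=C/c2cc(OC)cc(OC)c2/C=C/C(=O)c2ccc(Br)cc2)cc1` and its change is 4-bromophenyl in place of 3-chlorophenyl on a carbonyl carbon in short, 4-bromophenyl in place of 3-chlorophenyl on a carbonyl carbon. Among the measured compounds shown here, no measured compound carries bromo, so this exact change is untested.

For the measured compounds named here, the closest evidence is a 1.4-fold lower number from compound 1 to compound 2 (0.15 log units; within the scatter) and a 1.6-fold lower number from compound 2 to compound 3 (0.21 log units; within the scatter), both within the scatter, along with a 2.3-fold lower number from compound 1 to compound 3 (0.36 log units; beyond the scatter) as the only step beyond it. On that evidence, no step beyond the scatter is expected in this assay and any drift is expected to be slightly upward from the low end. The estimated step is a 1.4-fold higher number from compound 3 to compound 4 (0.13 log units; within the scatter) and it is expected to stay within the scatter. The estimate for compound 4 is 4.5 ug/mL with an expected range from 2.2 ug/mL to 9 ug/mL in this read-out.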

Compound 4, half-maximal inhibitory concentration: 6.5 ug/mL
The estimate for compound 4 lay 1.4-fold (0.16 log units) below the measured number, within the range that was stated.
By their numbers in this assay, from the lowest: compounds 3, 2, 4 and 1 (each within the scatter of the next, the first and the last beyond it).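

In this assay the carbonyl carbon takes 4-bromophenyl with no step beyond the scatter against any earlier compound, as shown by a 2.0-fold higher number from compound 3 to compound 4 (0.29 log units; within the scatter) and a 1.2-fold higher number from compound 2 to compound 4 (0.09 log units; within the scatter) and a 1.2-fold lower number from compound 1 to compound 4 (0.06 log units; within the scatter). Bromo therefore joins chloro and butoxy as a ring substituent in this series without widening the spread, and the only step beyond the scatter remains a 2.3-fold lower number from compound 1 to compound 3 (0.36 log units; beyond the scatter). No measurement shown here accounts for these values.

The change from compound 3 to compound 4 alters both the halogen and its ring position at once, so 4-chlorophenyl or 3-bromophenyl on the same carbonyl carbon would be needed to separate the two. Also open, from the compounds shown here alone, is how the series responds when the ring on the carbonyl carbon carries an amine or a carboxylic acid rather than a halogen or butoxy.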